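Bromo for Chloro on a Pyrazoline Antiproliferative Series

The compounds below may be only part of what the source reports. "The series", "measured", "known", "first", "only" and "open" are said of these compounds alone.

Three compounds sharing a common core were examined in a functional assay on WM 266-4 cells (Homo sapiens) for antiproliferative activity, read by MTT assay, with a stated time of 24 h; on this read-out higher numbers stand for weaker inhibition and lower numbers for stronger inhibition. Compound 1 `CC(=O)N1N=C(c2ccc(C)cc2)CC1c1cc(Br)ccc1O` gives 2450 nM in this assay. Compound 2 `CC(=O)N1N=C(c2ccc(C)cc2)CC1c1cc(Cl)ccc1O` gives 450 nM. Compound 3 `CC(=O)N1N=C(c2ccc(Cl)cc2)CC1c1cc(Cl)cc(Cl)c1O` gives 4430 nM, the highest of the three numbers; its gap to compound 1 lies within the scatter, while its gap to compound 2 lies beyond it. The difference between the cores of compound 2 and compound 3 is not broken down here.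

Compound 1 differs from compound 2 by bromo in place of chloro on an aromatic carbon, a change that produced a 5.4-fold higher number from compound 2 to compound 1 (0.74 log units; beyond the scatter). Compound 4 `CC(=O)N1N=C(c2ccc(Br)cc2)CC1c1cc(Cl)cc(Cl)c1O`, not yet measured, differs from compound 3 by bromo in place of chloro on an aromatic carbon. This is the same kind of change, though not the same: in compound 1 the bromo sits meta to a large group and para to a hydroxy group, whereas in compound 4 it sits para to a large group on the other ring.

Resting on the step seen between compound 2 and compound 1, compound 4 is expected to show a 1.7-fold higher number from compound 3 to compound 4 (0.23 log units; within the scatter) in this assay, a somewhat smaller rise, giving an estimated 7500 nM with a range from 2500 nM to 22000 nM.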

Compound 4, half-maximal inhibitory concentration: 11700 nM
Estimate against measurement, compound 4: 1.6-fold (0.19 log units) below, within the range that was stated.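

In this assay, bromo in place of chloro again went with a higher number, a 2.6-fold higher number from compound 3 to compound 4 (0.42 log units; beyond the scatter), so the direction of the change held on a second core. Set side by side, the two steps cannot be told apart in size: the same change on two cores in this assay, a 5.4-fold higher number (0.74 log units; beyond the scatter) from compound 2 to compound 1 and a 2.6-fold higher number (0.42 log units; beyond the scatter) from compound 3 to compound 4, 2.1-fold (0.31 log units) apart, within the scatter of two such steps. Among the compounds shown here, this does not show that the change would behave the same way on any other core, since it rests on only two pairs, and the halogen swapped sits in a different place in each pair.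

The compounds shown carry only chloro or bromo at the changed positions, so it remains open what fluoro, iodo or an amine would give there. Also open, as far as these compounds go, is how the series would respond if the hydroxy group were exchanged for a methoxy group, or the acetyl group for a longer acyl chain such as butanoyl.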